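Swapping trifluoromethyl for methoxy on the benzyl amide

The source may report more compounds than this note shows. Statements on the series, on what has been measured and on what is new or still open speak of the compounds shown alone.

Compound 1: `CC(C)c1c(C(=O)NCc2cccc(Cl)c2)nn(-c2ccc(F)cc2)c1OC[C@@H](O)C[C@@H](O)CC(=O)O`, 5.4 nM
Compound 2: `CC(C)c1c(C(=O)N(C)Cc2cccc(C(F)(F)F)c2)nn(-c2ccc(F)cc2)c1OC[C@@H](O)C[C@@H](O)CC(=O)O`, 31 nM

In an assay on microsomes from liver for inhibition of 3-hydroxy-3-methylglutaryl-coenzyme A reductase (Rattus norvegicus) (a lower number here means a stronger inhibitor, a higher number a weaker inhibitor), compound 2 has the higher of the two numbers; compound 1 gives 5.4 nM, a gap beyond the usual scatter. Compound 3, `COc1cccc(CN(C)C(=O)c2nn(-c3ccc(F)cc3)c(OC[C@@H](O)C[C@@H](O)CC(=O)O)c2C(C)C)c1`, differs from compound 2 by methoxy in place of trifluoromethyl on an aromatic carbon. For the measured compounds named here, no measured pair shows this change, so its effect is unknown. A small shift is expected, perhaps no larger than the scatter, leaning towards a weaker inhibitor: the step of a 1.6-fold higher number from compound 2 to compound 3 (0.21 log units; within the scatter) is the estimate. Compound 3 is expected to give 50 nM in this assay, between 15 nM and 160 nM.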

Compound 3, half-maximal inhibitory concentration: 21 nM
For compound 3 the middle estimate is 2.4-fold (0.38 log units) above the measured one; the measured number falls inside the stated range.
By their numbers in this assay, from the lowest: compound 1; then compounds 3 and 2 (each within the scatter of the next).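

In this assay, methoxy and trifluoromethyl on this aromatic carbon cannot be told apart: the swap gives a 1.5-fold lower number from compound 2 to compound 3 (0.17 log units; within the scatter). The larger replacement of (3-chlorobenzyl)amino by (3-methoxybenzyl)(methyl)amino does register, with a 3.9-fold higher number from compound 1 to compound 3 (0.59 log units; beyond the scatter). Nothing available explains either step.

Still open, as far as these compounds go, is how much of that larger step belongs to the methyl on the amide nitrogen and how much to the ring substituent. From the compounds shown here alone, it is also open whether ethoxy or an amine on the same carbon would give a similar number.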